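The source may report more compounds than this note shows. Statements on the series, on what has been measured and on what is new or still open speak of the compounds shown alone.

In a functional assay on cells (Panel NCI-60 (60 carcinoma cell lines), Homo sapiens) for inhibition, read by sulforhodamine B assay, with a stated time of 48 h (on this read-out higher numbers stand for weaker inhibition of growth and lower numbers for stronger inhibition of growth), compound 1 `O=S(=O)(Nc1ccc(Cl)cc1)c1ccc(-c2cnc(C3CC3)o2)cc1` gives 1430 nM, the higher of the two numbers measured, and compound 2 `O=S(=O)(Nc1ccc(Cl)c(C(F)(F)F)c1)c1ccc(-c2cnc(C3CC3)o2)cc1` gives 655 nM. Compound 3 `O=S(=O)(Nc1ccc(Br)cc1)c1ccc(-c2cnc(C3CC3)o2)cc1` departs from compound 1 by bromo in place of chloro on an aromatic carbon. Going by the values given here, the only measured step, a 2.2-fold lower number from compound 1 to compound 2 (0.34 log units; beyond the scatter), is modest and reflects a different change, trifluoromethyl in place of hydrogen on an aromatic carbon. It therefore offers only loose guidance, and in this assay a smaller shift, probably within the scatter, is expected. The expected step is a 1.2-fold lower number from compound 1 to compound 3 (0.08 log units; within the scatter). For compound 3 the estimated value is 1200 nM, with an expected range of 650 nM to 2200 nM.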

Compound 3, concentration for 50% growth inhibition: 2750 nM
Estimate against measurement, compound 3: 2.3-fold (0.36 log units) below; measured number outside the range, above it.
By their numbers in this assay, from the lowest: compound 2; then compounds 1 and 3 (each within the scatter of the next).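

In this assay, bromo in place of chloro on an aromatic carbon, para to a large group, gives a 1.9-fold higher number from compound 1 to compound 3 (0.28 log units; within the scatter) and so leaves the two halogens at this position indistinguishable. Compound 2 remains the only compound shown that stands apart from compound 1 by more than the scatter. Nothing available explains this result. Still open, going by these compounds, is whether fluoro would match chloro and bromo here, and whether an amine, a methoxy group or a carboxylic acid at this position would move the number beyond the scatter.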